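Compound 4: nitro in place of chloro

The source may report more compounds than this note shows. Statements on the series, on what has been measured and on what is new or still open speak of the compounds shown alone.

Going by the values given here, in an ADME assay on MT4 cells (Homo sapiens) for cytotoxicity, read by MTT assay (on this read-out higher numbers stand for lower toxicity in this test and lower numbers for higher toxicity in this test), three compounds have numbers so far. Compound 1 (`O=C(CSc1nncnc1-c1cccc2ccccc12)Nc1ccc(Cl)cc1Cl`) gives 254000 nM, the highest of the three. Compound 2 (`O=C(CSc1nncnc1-c1ccccc1Cl)Nc1ccccc1`) gives 127000 nM, within the scatter of the value for compound 1. Compound 3 (`COC(=O)c1sccc1NC(=O)CSc1nncnc1-c1ccccc1Cl`) gives 105000 nM, which stands apart from the value for compound 1 by more than the scatter.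

Compound 4 (`O=C(CSc1nncnc1-c1cccc2ccccc12)Nc1ccc([N+](=O)[O-])cc1Cl`) keeps the core of compound 1 and alters one group: nitro in place of chloro on an aromatic carbon. The 2,4-dichlorophenyl becomes 2-chloro-4-nitrophenyl, with the nitro on an aromatic carbon, meta to a chloro group and para to a large group.

Among the compounds with values here, no measured step exchanges chloro for nitro, so this change is untested. Within the data shown here, the only measured step, a 1.2-fold lower number from compound 2 to compound 3 (0.08 log units; within the scatter), replaces a whole group on the amide-type nitrogen and stays within the scatter. It bears on compound 4 only loosely, as a sign that changing this part of the molecule need not shift this assay much. No step beyond the scatter is therefore expected. The expected step is a 1.5-fold lower number from compound 1 to compound 4 (0.17 log units; within the scatter). For compound 4 the estimated value is 170000 nM, with an expected range of 70000 nM to 320000 nM.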

Compound 4, half-maximal cytotoxic concentration: 150000 nM
Compound 4: middle estimate off by 1.1-fold (0.05 log units), on the high side; the measured number falls inside the stated range.
By their numbers in this assay, from the lowest: compounds 3, 2, 4 and 1 (each within the scatter of the next, the first and the last beyond it).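

In this assay, nitro in place of chloro, on an aromatic carbon meta to a chloro group and para to a large group, gives a 1.7-fold lower number from compound 1 to compound 4 (0.23 log units; within the scatter) and so leaves the two compounds within the scatter of each other. Going by these compounds alone, this is the first measured exchange at this position, whereas the only earlier step replaced the whole group on the amide-type nitrogen; here 2,4-dichlorophenyl becomes 2-chloro-4-nitrophenyl, and a single substituent with 3 heavy atoms and 2 hydrogen-bond acceptors takes the place of one with 1 heavy atom and no acceptors without a step beyond the scatter. No evidence at hand bears on why this step has the size it has.

The compounds shown cover only chloro and nitro at this position, so it remains open whether an amine, a carboxylic acid or a longer chain here would also stay within the scatter of compound 1. Also open, on these data alone, is whether the chloro group retained in compound 4 can be exchanged for nitro with a similarly small step in this test.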